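The compounds below may be only part of what the source reports. "The series", "measured", "known", "first", "only" and "open" are said of these compounds alone.

In a functional assay on HEK293 cells for agonist activity at Free fatty acid receptor 1 (Homo sapiens), read by fluorescence and calcium flux (on this read-out lower numbers stand for an effect already at smaller amounts and higher numbers for an effect only at larger amounts of compound), compound 1 `CC#CC(CC(=O)O)c1ccc(OCc2ccc(C(=O)N3CCN(C)CC3)s2)cc1` gives only a limit, > 5000 nM, which is the limit recorded as the limit of > 5000 nM in this assay, at which 1 of the 3 values shown sits. Two related compounds carry an aryl group in place of the methyl on the amine nitrogen in the ring: compound 2 `CC#CC(CC(=O)O)c1ccc(OCc2ccc(C(=O)N3CCN(c4ccc([N+](=O)[O-])cc4)CC3)s2)cc1` gives 231 nM and compound 3 `CC#CC(CC(=O)O)c1ccc(OCc2ccc(C(=O)N3CCN(c4cccc(F)c4)CC3)s2)cc1` gives 97 nM, giving steps of an at least 21-fold lower number from compound 1 to compound 2 (1.33 log units; beyond the scatter) and an at least 51-fold lower number from compound 1 to compound 3 (1.71 log units; beyond the scatter), while between the two aryl compounds the step is a 2.4-fold lower number from compound 2 to compound 3 (0.38 log units; beyond the scatter). Compound 4 `CC#CC(CC(=O)O)c1ccc(OCc2ccc(C(=O)N3CCCc4ccccc43)s2)cc1` has not yet been measured. It differs from compound 1 by 1,2,3,4-tetrahydroquinolin-1-yl in place of 4-methylpiperazin-1-yl on a carbonyl carbon. The change again places an aromatic ring on the amide nitrogen, and the two measured steps therefore point to a large fall in the number, though the ring system entering is a different one. The estimate for compound 4 is 300 nM, between 80 nM and 2000 nM. This estimate would mean an expected step of an at least 16-fold lower number from compound 1 to compound 4 (1.22 log units; beyond the scatter).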

Compound 4, half-maximal effective concentration: 80 nM
For compound 4 the middle estimate is 3.8-fold (0.57 log units) above the measured one, within the range that was stated.
By their numbers in this assay, from the lowest: compounds 4 and 3 (each within the scatter of the next); then compound 2. At a limit, above all of these: compound 1.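

In this assay, 1,2,3,4-tetrahydroquinolin-1-yl in place of 4-methylpiperazin-1-yl on the carbonyl carbon brings an at least 62-fold lower number from compound 1 to compound 4 (1.79 log units; beyond the scatter). Unlike compound 2 and compound 3, which keep the ring of compound 1, compound 4 shows that a low number does not require that ring or its second nitrogen. Compound 1 is a limit, so this step is only a bound: the limit of > 5000 nM in this assay, at which 1 of the 4 values shown sits.

The compounds shown leave open whether the aromatic ring itself is needed, or whether a piperidin-1-yl group on the same carbonyl carbon would serve as well.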